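Methyl on the Ring Amine: What to Expect

This account rests on a few compounds, and the source may have more. Where it says the series, first, only, none or still open, it means among the compounds named here.

Measured compounds:
compound 1 `Clc1ccc(C2=CC3CNCC(C2)C3)cn1`: 141%
compound 2 `Fc1ccc(C2=CC3CNCC(C2)C3)cn1`: 140%
compound 3 `C1=C(c2cccnc2)C[C@H]2CNC[C@@H]1C2`: 142%

All three were tested in an in vitro functional assay on SH-SY5Y cells for agonist activity at Neuronal acetylcholine receptor; alpha3/beta4 (Homo sapiens), read by FLIPR and calcium flux; a lower number here means a smaller maximal response, a higher number a larger maximal response. Compound 2 sits at the low end of the three numbers, yet the step of a number 1 percentage points lower from compound 1 to compound 2 (within the scatter) and the gap to compound 3 both fall within the scatter, so the three behave alike. Compound 4 `CN1CC2C=C(c3ccc(F)nc3)CC(C2)C1` differs from compound 2 by methyl in place of hydrogen on an amine nitrogen in a ring. Going by the values given here, the only measured step, fluoro in place of chloro on an aromatic carbon, changed nothing beyond the scatter and concerns a different part of the molecule; no measured pair alters the amine nitrogen. Without such a precedent, a small or absent change is the expectation. For compound 4 the expected value is 130%, with a range from 95% to 155%. The estimated step is a number 10 percentage points lower from compound 2 to compound 4 (within the scatter).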

Compound 4, largest response reached (reported as percent of maximum), in percent of the reference or control that the assay uses: 25%
Compound 4: the middle estimate sits 105 percentage points above what was measured; measured number below the stated range.
By their numbers in this assay, from the lowest: compound 4; then compounds 2, 1 and 3 (each within the scatter of the next).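

The amine nitrogen in the ring proves to be a sensitive position. In this assay methyl in place of hydrogen there gives a number 115 percentage points lower from compound 2 to compound 4 (beyond the scatter) and so removes most of the response, although it adds a single carbon, whereas the earlier change on the aromatic carbon stayed within the scatter. Nothing available explains this loss.

The compounds shown leave open whether ethyl or a longer chain on this nitrogen lowers the response as well. They also leave open whether methyl has the same effect with chloro on the aromatic ring.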